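The compounds below may be only part of what the source reports. "The series", "measured", "known", "first", "only" and "open" are said of these compounds alone.

Measured so far in an assay on CHO cells for agonist activity at Neuronal acetylcholine receptor; alpha3/beta4 (Homo sapiens), read by FLIPR and calcium flux; a higher number here means that more compound is needed for the effect, a lower number that less compound is needed:
compound 1 `O=C(C1CC1)[C@H]1C[C@H]2CNC[C@H]2C1`: 930 nM
compound 2 `O=C(c1ccco1)[C@H]1C[C@H]2CNC[C@H]2C1`: 11000 nM

Compound 2 stands at the highest of the two numbers in this assay; its nearest neighbour is compound 1, and a 12-fold higher number from compound 1 to compound 2 (1.07 log units; beyond the scatter) separates the two. Compound 3 `COC(=O)[C@H]1C[C@H]2CNC[C@H]2C1` has not yet been measured. It differs from compound 2 in one place: methoxy in place of furan-2-yl on a carbonyl carbon. Among the measured compounds shown here, the one measured step that bears on this position is a 12-fold higher number from compound 1 to compound 2 (1.07 log units; beyond the scatter), which shows that the group on the carbonyl carbon moves the number well beyond the scatter. For the measured compounds named here, no step involving methoxy has been measured, so the direction can only be read from compound 1 and compound 2: cyclopropyl on the carbonyl carbon goes with the lower number, furan-2-yl with the higher. Going by the values given here, on that basis compound 3 is expected to come out below compound 2 rather than above it, with wide uncertainty because the only comparison available is a 12-fold higher number from compound 1 to compound 2 (1.07 log units; beyond the scatter). The estimate for compound 3 in this assay is 3000 nM, within 700 nM to 15000 nM, which would mean an expected 3.7-fold lower number from compound 2 to compound 3 (0.56 log units; beyond the scatter).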

Compound 3, half-maximal effective concentration: 14000 nM
Estimate against measurement, compound 3: 4.7-fold (0.67 log units) below; the range from low to high includes it.
By their numbers in this assay, from the lowest: compound 1; then compounds 2 and 3 (each within the scatter of the next).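

In this assay the step of a 1.3-fold higher number from compound 2 to compound 3 (0.10 log units; within the scatter) comes with methoxy in place of furan-2-yl on the carbonyl carbon, so these two groups cannot be told apart here, although only furan-2-yl carries a five-membered aromatic ring. The aromatic ring is therefore not needed for the higher number, and cyclopropyl now stands apart from two groups rather than one: a 15-fold higher number from compound 1 to compound 3 (1.18 log units; beyond the scatter) comes with methoxy in place of cyclopropyl and is large, in the same direction as a 12-fold higher number from compound 1 to compound 2 (1.07 log units; beyond the scatter) at this position. No evidence is available on what lies behind these differences.

Open, from the compounds shown here alone, is whether the lower number belongs to cyclopropyl alone or extends to other carbon groups on the carbonyl carbon, such as isopropyl, cyclobutyl or a longer alkyl chain. Also open, going by these compounds, is how an amine on the carbonyl carbon, which would turn the carbonyl into an amide, would compare with methoxy and cyclopropyl on the shared core.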